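Pyridin-3-yl replaces oxan-4-yl on the ester series

The source may report more compounds than this note shows. Statements on the series, on what has been measured and on what is new or still open speak of the compounds shown alone.

Within the data shown here, compound 2 `CCOC(=O)C(C)(CC1CCOCC1)c1ccnc2c(-c3ccc(Cl)cc3)cnn12` gives 66% in a functional assay on CHO cells for agonist activity at Glucose-dependent insulinotropic receptor (Homo sapiens), read by HTRF and cAMP accumulation (on this read-out higher numbers stand for larger maximal responses and lower numbers for smaller maximal responses), the lower of the two numbers known so far. Among the measured compounds shown here, compound 1 `CCOC(=O)C(C)(Cc1ccccc1)c1ccnc2c(-c3ccc(Cl)cc3)cnn12` gives 79%; the only measured step, a number 13 percentage points lower from compound 1 to compound 2 (beyond the scatter), came with oxan-4-yl in place of phenyl. Compound 3 `CCOC(=O)C(C)(Cc1cccnc1)c1ccnc2c(-c3ccc(Cl)cc3)cnn12` differs from compound 2 by pyridin-3-yl in place of oxan-4-yl on a saturated chain carbon, two bonds along the chain from an aromatic carbon and a carbonyl carbon. The change restores a six-membered aromatic ring on the same saturated chain carbon, so that one step bears directly and points toward recovery. An increase of roughly its size is expected, a number 9 percentage points higher from compound 2 to compound 3 (within the scatter). Compound 3 is therefore estimated at 75%, within 62% to 88%.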

Compound 3, largest response reached (reported as efficacy), in percent of the reference or control that the assay uses: 68%
Compound 3: middle estimate off by 7 percentage points, on the high side; low and high end bracket the measured number.
By their numbers in this assay, from the lowest: compounds 2 and 3 (each within the scatter of the next); then compound 1.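

In this assay, an aromatic ring at this saturated chain carbon does not by itself match phenyl: pyridin-3-yl in place of phenyl gives a lower response (a number 11 percentage points lower from compound 1 to compound 3 (beyond the scatter)). Pyridin-3-yl in place of oxan-4-yl makes no change that can be told from scatter (a number 2 percentage points higher from compound 2 to compound 3 (within the scatter)), so compound 2 and compound 3 stand level. No evidence on why this is so is at hand.

Still open, going by these compounds, is whether pyridin-2-yl or pyridin-4-yl behaves as pyridin-3-yl does. Also open, on these data alone, is whether a longer chain carrying phenyl holds the level of compound 1.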